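Swapping Propyl for Cyclopropylmethyl on Compound 2

The source may hold more compounds than are shown below. What is called first, only, known or untested is meant among the compounds shown, and "the series" means these compounds.

Among the measured compounds shown here, in an ADME assay on liver (Homo sapiens) for metabolic stability, read by LC-MS, using microsomes and NADPH (on this read-out lower numbers stand for a less stable compound and higher numbers for a more stable compound), compound 2 `CCCN(Cc1ccc(OCCn2c(=O)ccn(C)c2=O)c(OC)c1)C(CC(=O)O)c1ccc(Cl)cc1` gives 61%, the higher of the two numbers so far and beyond the scatter from the other one. Compound 3 `COc1cc(CN(CC2CC2)C(CC(=O)O)c2ccc(Cl)cc2)ccc1OCCn1c(=O)ccn(C)c1=O` is still unmeasured. It changes compound 2 by cyclopropyl in place of ethyl on a saturated chain carbon bound to an amine nitrogen, or propyl to cyclopropylmethyl. Compound 1 `Cc1cc(CN(CC2CC2)C(CC(=O)O)c2ccc(Cl)cc2)ccc1OCCn1c(=O)ccn(C)c1=O` also carries cyclopropylmethyl, differs elsewhere too, and gives 32%, so a moderate fall in this assay is expected. The expected change is a number 15 percentage points lower from compound 2 to compound 3 (beyond the scatter). For compound 3 the estimated value is 46%, with a range of 28% to 64%.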

Compound 3, percent of the compound remaining: 55%
Compound 3: middle estimate off by 9 percentage points, on the low side; measured number inside the range.
By their numbers in this assay, from the lowest: compound 1; then compounds 3 and 2 (each within the scatter of the next).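

In this assay, cyclopropyl in place of ethyl on a saturated chain carbon bound to an amine nitrogen gives a number 6 percentage points lower from compound 2 to compound 3 (within the scatter) and so brings no clear loss. The low number of compound 1 goes instead with the other place: methoxy in place of methyl on an aromatic carbon gives a number 23 percentage points higher from compound 1 to compound 3 (beyond the scatter) with cyclopropylmethyl held constant. Nothing measured here explains either step.

As far as these compounds go, whether a longer chain such as butyl fits the amine equally well remains open. So does whether an ethoxy group on that aromatic carbon would do the same as methoxy.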